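Allyl for cyclopropyl on the ring nitrogen

This account rests on a few compounds, and the source may have more. Where it says the series, first, only, none or still open, it means among the compounds named here.

Values in a functional assay on HL-60 cells (Homo sapiens) for inhibition (a lower number here means a stronger inhibitor, a higher number a weaker inhibitor), so far:
compound 1 `COc1ccc(-c2cc(O)nnc2-c2ccc(OC)cc2)cc1` gives 31600 nM
compound 2 `COc1ccc(-c2cc(=O)n(CC(C)C)nc2-c2ccc(OC)cc2)cc1` gives > 100000 nM (a limit of the assay)
compound 3 `COc1ccc(-c2cc(=O)n(C3CC3)nc2-c2ccc(OC)cc2)cc1` gives 7980 nM

Among the actual numbers, compound 3 at 7980 nM is the lower one, and compound 1 at 31600 nM stands higher by more than the scatter. The entry for compound 2 is a limit, not a number.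

Compound 4 `C=CCn1nc(-c2ccc(OC)cc2)c(-c2ccc(OC)cc2)cc1=O` is still unmeasured. It carries allyl in place of cyclopropyl on an aromatic nitrogen and otherwise matches compound 3. For the measured compounds named here, the one measured step at this nitrogen, an at least 12-fold lower number from compound 2 to compound 3 (1.09 log units; beyond the scatter) with cyclopropyl in place of isobutyl, is large. Allyl has no ring, and neither has the isobutyl of compound 2, so part of that gain may be lost again. A single step is thin ground, and allyl also differs from isobutyl, so a full return to the limit is not assumed. The expected change in this assay is a 2.5-fold higher number from compound 3 to compound 4 (0.40 log units; beyond the scatter) towards weaker inhibition, of smaller size than the measured step. Compound 4 is estimated at 20000 nM with an expected range of 6000 nM to 80000 nM around that figure.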

Compound 4, half-maximal inhibitory concentration: > 100000 nM
Compound 4: no number, only a limit (the forecaster's own chance of this, stated with the estimate: 20%); middle value at least 5.0-fold (0.69 log units) from the limit.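

In this assay, allyl and cyclopropyl both have 3 heavy atoms, all carbon, yet the change gives an at least 12-fold higher number from compound 3 to compound 4 (1.09 log units; beyond the scatter), so the heavy-atom count of the group on this aromatic nitrogen does not settle the read-out. Among the substituted compounds, both open-chain groups, isobutyl in compound 2 and allyl in compound 4, end at a limit of the assay, and only the cyclopropyl of compound 3 gives a number; compound 1, with no group on this nitrogen, also gives a number and so stands outside this comparison. The step from compound 2 to compound 4 cannot be read, both entries being limits: the limit of > 100000 nM in this assay, at which 2 of the 4 values shown sit.

On these data alone, it remains open whether a number at this nitrogen goes with cyclopropyl alone or with rings more widely, which cyclobutyl set against a plain methyl or ethyl would help to separate. Also open, as far as these compounds go, is how a group carrying an amine or a carboxylic acid would read at this nitrogen on the shared core.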